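Putting a Hydroxyphenyl Group Where the Naphthyl Stood

The source may report more compounds than this note shows. Statements on the series, on what has been measured and on what is new or still open speak of the compounds shown alone.

Among the compounds with values here, compound 3 `COc1cc(N2C(N)=C(C#N)C(c3c(OC)ccc4ccccc34)C3=C2CC(C)(C)CC3=O)cc(OC)c1OC` gives 10% in a functional assay on Ehrlich cells (Mus musculus) for cytotoxicity, tested at 50 ug/mL (a higher number here means a stronger effect of the compound at the concentration tested, a lower number a weaker effect), the lowest of the three numbers measured so far. Compound 1 `COc1cc(N2C(N)=C(C#N)C(c3ccc([N+](=O)[O-])cc3)C3=C2CC(C)(C)CC3=O)cc(OC)c1OC` gives 70% and compound 2 `COc1cc(N2C(N)=C(C#N)C(c3ccc(C)cc3)C3=C2CC(C)(C)CC3=O)cc(OC)c1OC` gives 60% in this assay; the step of a number 10 percentage points lower from compound 1 to compound 2 (within the scatter) stays within the scatter. Within the data shown here, two steps bear on the next move: a number 60 percentage points lower from compound 1 to compound 3 (beyond the scatter) and a number 50 percentage points lower from compound 2 to compound 3 (beyond the scatter), both large drops when 2-methoxynaphthalen-1-yl entered in place of a phenyl-type group. Compound 4 `COc1cc(N2C(N)=C(C#N)C(c3ccccc3O)C3=C2CC(C)(C)CC3=O)cc(OC)c1OC` goes the other way: 2-hydroxyphenyl in place of 2-methoxynaphthalen-1-yl on a saturated ring carbon. Because a number 50 percentage points lower from compound 2 to compound 3 (beyond the scatter) was so large a fall, a rise of similar order is expected in this assay, a number 45 percentage points higher from compound 3 to compound 4 (beyond the scatter). Compound 4 is therefore estimated at 55%, with a range from 30% to 75%.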

Compound 4, a percentage reported as activity, at one concentration (the size of the read-out at that concentration, not a potency): 2%
Beside the measured number, compound 4's estimate is 53 percentage points above it, and the stated range ends above it.
By their numbers in this assay, from the lowest: compounds 4 and 3 (each within the scatter of the next); then compounds 2 and 1 (each within the scatter of the next).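

In this assay, 2-hydroxyphenyl in place of 2-methoxynaphthalen-1-yl gave a number 8 percentage points lower from compound 3 to compound 4 (within the scatter), so a low number at this saturated ring carbon occurs with one six-membered aromatic ring as well as with two. Against the other two groups, the change gave a number 58 percentage points lower from compound 2 to compound 4 (beyond the scatter) and a number 68 percentage points lower from compound 1 to compound 4 (beyond the scatter). Nothing available explains these differences.

As far as these compounds go, what remains open is whether the low number follows the hydroxyl group or the substitution pattern of the ring. A 4-hydroxyphenyl or a 2-methoxyphenyl group on this carbon would separate the two.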